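Anilide nitrogen substituent change in a dimethylphenyl series

The source may hold more compounds than are shown below. What is called first, only, known or untested is meant among the compounds shown, and "the series" means these compounds.

Three compounds share one core. Compound 1 `CC(=O)N(Cc1ccc(OCCF)cc1)c1cc(C)cc(C)c1` gives 3930 nM in an assay on HEK293 cells for displacement of a labelled ligand from Translocator protein (Homo sapiens), read by scintillation counting, with a stated time of 90 min (a lower number here means a stronger inhibitor, a higher number a weaker inhibitor), the highest of the three numbers; compound 2 `CC(=O)N(Cc1ccc(OC(C)C)cc1)c1cc(C)cc(C)c1` gives 3150 nM, and compound 3 `CC(=O)N(Cc1ccc(OCc2ccccc2)cc1)c1cc(C)cc(C)c1` gives 738 nM. The step of a 1.2-fold lower number from compound 1 to compound 2 (0.10 log units; within the scatter) lies within the scatter, while a 5.3-fold lower number from compound 1 to compound 3 (0.73 log units; beyond the scatter) and a 4.3-fold lower number from compound 2 to compound 3 (0.63 log units; beyond the scatter) are modest. All three measured steps change the substituent on the oxygen on the aromatic ring. Compound 4 `CCN(CC)C(=O)CN(Cc1ccc(OCCF)cc1)c1cc(C)cc(C)c1` differs from compound 1 elsewhere: (diethylcarbamoyl)methyl in place of acetyl on a nitrogen on an aromatic ring. None of the three steps touches this nitrogen, so they give no direction for the size of the change. For compound 4 the change is expected, with little to go on, to give a 2.6-fold lower number from compound 1 to compound 4 (0.42 log units; beyond the scatter). Compound 4 is therefore estimated at 1500 nM, within a wide range from 300 nM to 8000 nM.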

Compound 4, inhibition constant: > 10000 nM
Compound 4: no number, only a limit (the forecaster's own chance of this, stated with the estimate: 5%); middle value at least 6.6-fold (0.82 log units) away from the limit.
By their numbers in this assay, from the lowest: compound 3; then compounds 2 and 1 (each within the scatter of the next). At a limit, above all of these: compound 4.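

Going by these compounds alone, on a nitrogen on an aromatic ring, a position the earlier steps left untouched, (diethylcarbamoyl)methyl in place of acetyl gives an at least 2.5-fold higher number from compound 1 to compound 4 (0.40 log units; beyond the scatter), so the change moves toward a weaker inhibitor in this assay. Compound 4 gives > 10000 nM, which is a limit of the assay and not a number, so only a minimum size for this step can be read: the limit of > 10000 nM in this assay, at which 1 of the 4 values shown sits.

On these data alone, how a plain ethyl or a longer chain ending in an amine on this nitrogen would read stays open. Also open, as far as these compounds go, is whether the change carries over with benzyl in place of 2-fluoroethyl on the oxygen.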